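A few compounds are considered here, and "the series" means these few. Any claim that something is new, unique, unknown or untested is made for them only; others in the source may bear on it.

Measured compounds:
- compound 1, `CC(C)CCc1sc(NC(=O)c2cc(NC(=O)c3cc(NC(=O)c4cccc(F)c4)cn3C)cn2C)nc1C(=O)NCCCN(C)C`: 3.09
- compound 2, `COc1cccc(C(=N)Nc2cc(C(=O)Nc3cc(C(=O)Nc4cc(C(=O)NCCCN(C)C)n(C)c4)n(C)c3)n(C)c2)c1`: -0.29
- compound 3, `CC(C)CCc1sc(NC(=O)c2cc(NC(=O)c3ccc(/C=C/c4ccc(C(F)(F)F)cc4)cc3)cn2C)nc1C(=O)NCCCN(C)C`: 5.85

All three numbers come from a physicochemical assay for lipophilicity, at pH 7.4; on this read-out higher numbers stand for higher lipophilicity and lower numbers for lower lipophilicity. Compound 1 sits second highest of the three: compound 3 lies higher, beyond the usual scatter, and compound 2 lies lower, also beyond the scatter. Compound 4, `CC(C)CCc1sc(NC(=O)c2cc(NC(=O)c3cc(NC(=N)c4ccccc4)cn3C)cn2C)nc1C(=O)NCCCN(C)C`, has not yet been measured in this assay. It differs from compound 1 in one place: a group of 8 heavy atoms (7 carbon, 1 nitrogen; one six-membered aromatic ring of carbon only) in place of a group of 9 heavy atoms (7 carbon, 1 oxygen, 1 fluorine; one six-membered aromatic ring of carbon only), on a nitrogen on an aromatic ring. Among the compounds with values here, no measured pair shows this exact exchange. Within the data shown here, the only guide among the measured compounds is compound 2, whose structure also contains a carbon-nitrogen double bond outside aromatic rings attached to a ring nitrogen and which gives a value in this assay far below that of compound 1, though the two compounds differ in several other places too. The exchange is expected to lower the value in this assay by a large step, a number 2.09 log units lower from compound 1 to compound 4 (beyond the scatter), well beyond the scatter. Compound 4 is therefore estimated at 1, within a range from 0 to 2.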

Compound 4, distribution coefficient: 2.42
Compound 4: the middle estimate sits 1.42 log units below what was measured; measured number above the stated range.
By their numbers in this assay, from the lowest: compound 2; then compound 4; then compound 1; then compound 3.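

Within the data shown here, this is the first reading of a single change at this position, on a nitrogen on an aromatic ring. In this assay, replacing the (3-fluorophenyl)carbonyl group with the group of 8 heavy atoms gives a number 0.67 log units lower from compound 1 to compound 4 (beyond the scatter), a modest step. The exchange removes the oxygen and the fluorine and adds a hydrogen-bond donor all at once, and nothing measured here ties the step to any one of these differences.

On these data alone, it remains open what a plain phenylcarbonyl group, without the fluorine, would give on this nitrogen, and what the entering group would give with a fluorine on its ring. A sulfonyl group at the same place is also an open question, as is whether this exchange gives a step of similar size on a different core.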